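Swapping Trifluoromethyl for Methylsulfanyl on a Chemokine Antagonist

This account rests on a few compounds, and the source may have more. Where it says the series, first, only, none or still open, it means among the compounds named here.

Measured compounds:
- compound 1, `Fc1cccc(NCc2ccc(CNc3cccc(F)n3)cc2)n1`, 85%
- compound 2, `Fc1cnc(NCc2ccc(CNc3ncc(F)cn3)cc2)nc1`, 75%
- compound 3, `Fc1cnc(NCc2ccc(CNc3nccc(C(F)(F)F)n3)cc2)nc1`, 93%

All three were tested in a functional assay on MDA-MB-231 cells for antagonist activity at C-X-C chemokine receptor type 4 (Homo sapiens), tested at 100 nM; on this read-out lower numbers stand for a weaker effect and higher numbers for a stronger effect at the one concentration tested. On this read-out compound 3 gives 93%, the highest of the three numbers. The number for compound 1, 85%, lies within the usual scatter of that for compound 3, so the two cannot be told apart. The number for compound 2, 75%, lies beyond the scatter and is the only one that clearly stands lower.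

Compound 4, `CSc1ccnc(NCc2ccc(CNc3ncc(F)cn3)cc2)n1`, has not yet been measured in this assay. It differs from compound 3 in one place:

methylsulfanyl in place of trifluoromethyl on an aromatic carbon

Going by the values given here, no pair of measured compounds differs in only this one place, so the measured numbers give no direct guide to the size of this step. Starting from the number for compound 3, the step in this assay from compound 3 to compound 4 is expected to be small, downward or none beyond the scatter, estimated as a number 8 percentage points lower from compound 3 to compound 4 (within the scatter). On that basis compound 4 is estimated to give 85% in this assay, with a range from 65% to 98%.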

Compound 4, a percentage reported as inhibition, at one concentration (the size of the read-out at that concentration, not a potency): 92%
The estimate for compound 4 lay 7 percentage points below the measured number, and the stated range covers the measured number.
By their numbers in this assay, from the lowest: compounds 2, 1, 4 and 3 (each within the scatter of the next, the first and the last beyond it).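

In this assay, the step of a number 1 percentage points lower from compound 3 to compound 4 (within the scatter) shows that methylsulfanyl can take the place of trifluoromethyl on this aromatic carbon without a difference the measurement can resolve, although the entering group has 2 heavy atoms and the leaving group has 4. The step of a number 17 percentage points higher from compound 2 to compound 4 (beyond the scatter) adds a contrast: exchanging the whole ring group on this amine nitrogen, rather than only the group on its aromatic carbon, does produce a change beyond the usual scatter, so this end of the molecule is not indifferent to what it carries. Nothing measured here explains why the two groups give such similar numbers.

As far as these compounds go, whether this aromatic carbon would accept almost any group remains open, since a methoxy group, an amine or a longer sulfur-linked chain such as ethylsulfanyl could show how far the tolerance extends. The read-out comes from a single concentration and is not a potency. Compound 3 and compound 4 could also still separate in a full concentration series.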